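Swapping phenoxymethyl for phenyl in a series at its limit

A few compounds are considered here, and "the series" means these few. Any claim that something is new, unique, unknown or untested is made for them only; others in the source may bear on it.

Compounds measured in an ADME assay on RAW264.7 cells (Mus musculus) for cytotoxicity, read by MTT assay, with a stated time of 24 h, in the absence of a further agent (on this read-out higher numbers stand for weaker inhibition and lower numbers for stronger inhibition), each giving a limit and not a number:
Compound 1 `COc1ccc(C(O)C2OC(=O)c3c(OC)cc(OC)cc32)cc1` gives the limit > 40000 nM
Compound 2 `CCCOc1ccc(C(O)C2OC(=O)c3c(OC)cc(OC)cc32)cc1` gives the limit > 40000 nM
Compound 3 `COc1cc(OC)c2c(c1)C(C(O)c1ccc(OCCOc3ccccc3)cc1)OC2=O` gives the limit > 40000 nM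

Compound 3 has no number of its own, and the series shares one reading, (the limit of > 40000 nM in this assay, at which 3 of the 3 values shown sit), with nothing to rank its members.

In compound 4 `COc1cc(OC)c2c(c1)C(C(O)c1ccc(OCc3ccccc3)cc1)OC2=O`, phenyl takes the place of phenoxymethyl on a saturated chain carbon bound to an oxygen on an aromatic ring (phenyl in place of phenoxymethyl on a saturated chain carbon bound to an oxygen on an aromatic ring). Cut one bond further out, the same difference reads 2-phenoxyethoxy to benzyloxy.

Three measured changes touch this same chain: a step that the two limits leave unreadable from compound 1 to compound 2, a step that the two limits leave unreadable from compound 1 to compound 3 and a step that the two limits leave unreadable from compound 2 to compound 3. None of them has a size that can carry over, yet none of them moved the reading off the limit. No step beyond the scatter is therefore expected in this assay, in either direction.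

The expected change is a step that the limit leaves unreadable from compound 3 to compound 4, which would leave the reading where it stands.

For compound 4 the estimated value is 50000 nM, within an expected range from 25000 nM to 100000 nM, and a report of only a limit is the likeliest outcome.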

Compound 4, half-maximal inhibitory concentration: > 40000 nM
Compound 4: only a limit was reported; the forecaster's own chance of this, stated with the estimate: 85%; the middle value lies beyond the limit too.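

Compound 4 also gives only a limit in this assay, so no step from compound 1, compound 2 or compound 3 to compound 4 can be read, because all four share one reading: the limit of > 40000 nM in this assay, at which 4 of the 4 values shown sit.

The compounds shown leave open whether the groups on this chain differ at all in this assay, as none of the four has a number of its own.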